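A Series at Its Limit and the Step to Compound 4

The source may report more compounds than this note shows. Statements on the series, on what has been measured and on what is new or still open speak of the compounds shown alone.

Of the compounds shown here, three sharing one core have been tested so far. In a functional assay on the whole organism (stomach) with Rattus norvegicus as the target (a lower number here means that less compound is needed, a higher number that more compound is needed for the effect), compound 3 `N/N=C(\S)C1(c2ccccn2)CCCS1` gives > 30 mg/kg, which is a limit of the assay and not a number. Compound 1 `C=CCNC(=S)C1(c2ccccn2)CCCS1` gives > 30 mg/kg in this assay, again only a limit. Compound 2 `CN(C)CC/N=C(\S)C1(c2ccccn2)CCCS1` gives > 30 mg/kg in this assay, and this too is a limit. Compound 3 therefore has no exact place in the series, and the overall picture is the limit of > 30 mg/kg in this assay, at which 3 of the 3 values shown sit.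

The next compound to be measured is compound 4 `CN(C)C(=S)C1(c2ccccn2)CCCS1`. Its difference from compound 3 is a group of 5 heavy atoms (3 carbon, 1 nitrogen, 1 sulfur; no ring) in place of a group of 4 heavy atoms (1 carbon, 2 nitrogen, 1 sulfur; no ring), on a saturated ring carbon, on a saturated ring carbon next to the ring sulfur. For the measured compounds named here, the only measured step that bears on this change is a step that the two limits leave unreadable from compound 2 to compound 3. It alters the same group, but both of its ends are limits, so it offers no size to carry over.

Compound 4 is expected to remain in the same region because of the limit of > 30 mg/kg in this assay, at which 3 of the 3 values shown sit. The step that the limit leaves unreadable from compound 3 to compound 4 is estimated with no firm direction, and a further limit is the most likely report. The estimated value for compound 4 is 45 mg/kg, with an expected range from 15 mg/kg to 120 mg/kg.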

Compound 4, dose for half-maximal effect: < 30 mg/kg
Compound 4: a limit, no number; the forecaster's own chance of this, stated with the estimate: 75%; at least 1.5-fold (0.17 log units) between middle value and limit.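

In this assay, for the compounds shown here, compound 4 gives < 30 mg/kg, which is a limit of the assay and not a number, and it is the first compound with a limit on the lower side. Going by these compounds alone, this shows that a change at this saturated ring carbon, next to the ring sulfur, can take the series past the limit where the earlier compounds stayed, with a number no higher from compound 3 to compound 4 (the limit leaves the size open) as the step, and that the thiocarbonyl carbon can carry dimethylamino in a compound that does so, whereas allylamino in that place did not, with a number no higher from compound 1 to compound 4 (the limit leaves the size open) as the step; the sizes of these steps cannot be read, as limits stand at their ends. The series now divides on the two sides of a single limit, with most compounds still on the upper side: the limit of > 30 mg/kg in this assay, at which 3 of the 4 values shown sit.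

How far compound 4 lies on its side of the limit stays open, since no compound shown has an exact value, and so the gain from dimethylamino has no size. As far as these compounds go, it also stays open whether methylamino or diethylamino on the same thiocarbonyl carbon would fall on the same side of the limit as dimethylamino.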